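From 4-methylphenyl to 2-methylphenyl on a sulfur

This account rests on a few compounds, and the source may have more. Where it says the series, first, only, none or still open, it means among the compounds named here.

In a functional assay on A549 cells (Homo sapiens) for antiproliferative activity, read by MTT assay, with a stated time of 72 h (a higher number here means a weaker inhibitor, a lower number a stronger inhibitor), compound 1 `CC(C)(C)c1ccc(SC(=S)N2CCCCC2)cc1` gives 9130 nM, compound 2 `Cc1ccc(SC(=S)N2CCN(C(=O)OC(C)(C)C)CC2)cc1` gives 2110 nM and compound 3 `COc1ccc(SC(=S)N2CCN(C(=O)OC(C)(C)C)CC2)cc1` gives 712 nM. Compound 2 therefore stands in the middle of the three numbers, with compound 3 lower and compound 1 higher, both gaps beyond the scatter.

Compound 4 `Cc1ccccc1SC(=S)N1CCN(C(=O)OC(C)(C)C)CC1` has yet to be measured. It holds the same atoms as compound 2, joined differently: 2-methylphenyl in place of 4-methylphenyl on a sulfur. One measured step changes the same group, with methoxy in place of methyl on an aromatic carbon: a 3.0-fold lower number from compound 2 to compound 3 (0.47 log units; beyond the scatter). For the measured compounds named here, that modest step replaces a group rather than moving one, and no measured pair shows what moving the methyl does. Compound 1 differs from compound 2 in more than one place, so it offers no clean comparison.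

The central expectation is therefore no step beyond the scatter, with no firm direction, although a modest step remains possible. The expected change is a 1.2-fold higher number from compound 2 to compound 4 (0.09 log units; within the scatter). For compound 4 the estimated value is 2600 nM, with an expected range of 900 nM to 7000 nM.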

Compound 4, half-maximal inhibitory concentration: 2270 nM
The estimate for compound 4 lay 1.1-fold (0.06 log units) above the measured number; low and high end bracket the measured number.
By their numbers in this assay, from the lowest: compound 3; then compounds 2 and 4 (each within the scatter of the next); then compound 1.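

In this assay, for the compounds shown here, the step shows a 1.1-fold higher number from compound 2 to compound 4 (0.03 log units; within the scatter), so on a sulfur whose other neighbour is the thiocarbonyl carbon, 2-methylphenyl and 4-methylphenyl cannot be told apart; the earlier compounds replaced a group but never moved one. The second step, a 3.2-fold higher number from compound 3 to compound 4 (0.50 log units; beyond the scatter), shows that the 4-methoxyphenyl compound stands apart from the methyl compound whichever of these two forms the methyl takes. Nothing available here accounts for either result.

Whether methoxy, moved in the same way, would behave as methyl does remains open, since only one moved group is shown. So does the effect of a quite different group on the aromatic ring, such as an amine or a carboxylic acid.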